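A second fluoro on a series sitting at the limit

The source may hold more compounds than are shown below. What is called first, only, known or untested is meant among the compounds shown, and "the series" means these compounds.

Of the compounds shown here, three have been read so far in an ADME assay on HaCaT cells (Homo sapiens) for cytotoxicity, read by MTT assay, with a stated time of 48 h; on this read-out higher numbers stand for weaker inhibition and lower numbers for stronger inhibition. Compound 1 (`c1ccc(-c2nn(-c3ccccc3)cc2-c2nc3ccccc3[nH]2)cc1`) gives > 50000 nM, a limit of the assay and not a number. Compound 2 (`Fc1ccc2[nH]c(-c3cn(-c4ccccc4)nc3-c3ccccc3)nc2c1`) gives > 50000 nM, again a limit. Compound 3 (`Fc1ccc(-c2nn(-c3ccccc3)cc2-c2nc3ccccc3[nH]2)cc1`) gives > 50000 nM, also a limit, so its place is known only as a bound. The whole picture in this assay is the limit of > 50000 nM in this assay, at which 3 of the 3 values shown sit.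

Compound 4 (`Fc1ccc(-c2nn(-c3ccccc3)cc2-c2nc3cc(F)ccc3[nH]2)cc1`) follows from compound 3 by one change: fluoro in place of hydrogen on an aromatic carbon. It thereby carries both of the fluoro groups that compound 2 and compound 3 each carry singly.

Going by the values given here, two measured steps bear on this, each a fluoro in place of hydrogen on an aromatic carbon: a step that the two limits leave unreadable from compound 1 to compound 2 and a step that the two limits leave unreadable from compound 1 to compound 3. Neither has a size that can be read, and neither produced a number in this assay. No step beyond the scatter is therefore expected, and no direction can be argued. The expected change is a step that the limit leaves unreadable from compound 3 to compound 4, and a further report as a limit is the likeliest outcome. The estimate for compound 4 is 60000 nM, with an expected range of 30000 nM to 120000 nM.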

Compound 4, half-maximal inhibitory concentration: > 50000 nM
Compound 4 ended at the assay's limit; the forecaster's own chance of this, stated with the estimate: 85%; the middle value does not contradict the limit.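

In this assay compound 4 gives > 50000 nM, a limit and not a number. No new step can be read, either from compound 2 or from compound 3 to compound 4. The compounds shown leave open whether any fluoro replacement on this core changes the read-out, since the series offers only one bound: the limit of > 50000 nM in this assay, at which 4 of the 4 values shown sit.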